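Removing a ring hydroxy from an inactive pair

The source may hold more compounds than are shown below. What is called first, only, known or untested is meant among the compounds shown, and "the series" means these compounds.

Compound 1 `Cc1cn([C@@H]2O[C@H](CO)[C@@H](CO)[C@H]2O)c(=O)[nH]c1=O` and compound 2 `Cc1cn([C@@H]2O[C@H](CO)[C@@H](CN)[C@@H]2O)c(=O)[nH]c1=O` were both tested in a functional assay on L1210 cells (Mus musculus) for antiproliferative activity, with a stated time of 72 h; a lower number here means that less compound is needed, a higher number that more compound is needed for the effect. For compound 1 the outcome is only a limit of the assay, > 100 uM. Compound 2 likewise gives only a limit, > 100 uM. Within the data shown here, both results sit at the limit of > 100 uM in this assay, at which 2 of the 2 values shown sit, so neither compound shows measurable antiproliferative activity and no step between measured compounds can be given a size.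

Compound 3 `Cc1cn([C@H]2C[C@H](CO)[C@@H](CO)O2)c(=O)[nH]c1=O` differs from compound 1 by hydrogen in place of hydroxy on a saturated ring carbon. Whether this change matters cannot be read from the measured pair, since both start at the limit. Because compound 1 stands only at the limit of > 100 uM in this assay, at which 2 of the 2 values shown sit, the step from compound 1 to compound 3 is expected to be a number no higher from compound 1 to compound 3 (the limit leaves the size open), that is none beyond the scatter. Compound 3 is therefore estimated at 100 uM, most likely once more only a limit, within a range of 30 uM to 300 uM.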

Compound 3, concentration for half-maximal effect: 50 uM
Beside the measured number, compound 3's estimate is 2.0-fold (0.30 log units) above it; the range from low to high includes it.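

Among these compounds, compound 3 is the first compound here to give a real number in this assay, 50 uM, which shows that a change at this saturated ring carbon can yield a measurable result. Replacing hydroxy with hydrogen gives an at least 2.0-fold lower number from compound 1 to compound 3 (0.30 log units; that floor lies within the scatter). The true size stays unknown, and the printed figure is only a floor because compound 1 stands at a limit: the limit of > 100 uM in this assay, at which 2 of the 3 values shown sit.

As far as these compounds go, it remains open how far compound 3 truly lies from compound 1, and how other groups at this ring carbon, such as a fluorine atom or a methoxy group, would behave in this assay. Also open, from the compounds shown here alone, is whether the same replacement would bring a measurable number to compound 2, which carries an aminomethyl group and stands at the limit > 100 uM.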